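The source may hold more compounds than are shown below. What is called first, only, known or untested is meant among the compounds shown, and "the series" means these compounds.

Measured compounds:
Compound 1, `O=c1[nH]c(=O)n([C@H]2C[C@H](O)[C@@H](CO)O2)cc1C#CCCO`. In a functional assay on L1210 cells (Mus musculus) (on this read-out lower numbers stand for stronger inhibition and higher numbers for weaker inhibition), compound 1 gives > 1000 ug/mL, a limit of the assay rather than a number.
Compound 2, `CCCC/C=C\c1cn([C@H]2C[C@H](O)[C@@H](CO)O2)c(=O)[nH]c1=O`. In this assay compound 2 gives 361 ug/mL.
Compound 3, `O=c1[nH]c(=O)n([C@H]2C[C@H](O)[C@@H](CO)O2)cc1C#Cc1ccccc1`. In this assay compound 3 gives 494 ug/mL.

Compound 1 stands at the edge of what this assay reports: the limit of > 1000 ug/mL in this assay, at which 1 of the 3 values shown sits. Its true position relative to the others is therefore open; the two steps away from it, an at least 2.7-fold lower number from compound 1 to compound 2 (0.44 log units; beyond the scatter) and an at least 2.0-fold lower number from compound 1 to compound 3 (0.30 log units; that floor lies within the scatter), are both floors, and only the first of them is beyond the scatter. Compound 2 and compound 3 differ by a 1.4-fold higher number from compound 2 to compound 3 (0.14 log units; within the scatter), within the scatter.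

Compound 4, `O=c1[nH]c(=O)n([C@H]2C[C@H](O)[C@@H](CO)O2)cc1C#CCO`, differs from compound 1 by hydroxy in place of hydroxymethyl on a saturated chain carbon bound to a triple-bonded carbon. Both measured steps from compound 1 exchange the hydroxy-bearing alkynyl chain for a hydrocarbon group; none shortens that chain while keeping the hydroxy. Going by the values given here, nothing among the measured steps therefore points to a change beyond the scatter for this shortening, and compound 1 itself is known only as a limit. Compound 4 is expected to give 1000 ug/mL, with a range of 300 ug/mL to 3000 ug/mL. The step this estimate implies is a number no higher from compound 1 to compound 4 (the limit leaves the size open), expected to stay within the scatter, and a limit reading like that of compound 1 is the likelier outcome.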

Compound 4, concentration for 50% inhibition: > 1000 ug/mL
Compound 4 was reported as a limit; the forecaster's own chance of this, stated with the estimate: 60%; the middle value lies on the limit itself.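

In this assay compound 4 gives > 1000 ug/mL, a limit of the assay and not a number. With 3-hydroxyprop-1-yn-1-yl as with 4-hydroxybut-1-yn-1-yl, the hydroxy-bearing chains in the four compounds shown give no reading inside the range, and the comparison with the two hydrocarbon groups now gives an at least 2.7-fold higher number from compound 2 to compound 4 (0.44 log units; beyond the scatter), and an at least 2.0-fold higher number from compound 3 to compound 4 (0.30 log units; that floor lies within the scatter). The step between compound 1 and compound 4 cannot be read, so the shortening has no measurable size, and the top of the range is now shared: the limit of > 1000 ug/mL in this assay, at which 2 of the 4 values shown sit.

From the compounds shown here alone, what an amine or a carboxylic acid in place of the hydroxy would give remains open, as does the reading for a longer chain such as 5-hydroxypent-1-yn-1-yl. Also open, going by these compounds, is whether the hydroxy itself keeps compound 1 and compound 4 at the limit, as the step to compound 2 changes the hydroxy and the triple bond together, and a hex-1-yn-1-yl group would separate the two.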